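Para-substituent swap on the aryl ketone: hydroxy to chloro

This account rests on a few compounds, and the source may have more. Where it says the series, first, only, none or still open, it means among the compounds named here.

Measured so far in a functional assay on MCF7 cells (Homo sapiens) for cytotoxicity, read by sulforhodamine B assay, with a stated time of 24 h; on this read-out lower numbers stand for stronger inhibition of growth and higher numbers for weaker inhibition of growth:
- compound 1 `COc1ccc(C(=O)/C=C/c2cc3ccccc3[nH]c2=O)cc1`: 2860 nM
- compound 2 `O=C(/C=C/c1cc2ccccc2[nH]c1=O)c1ccc(O)cc1`: 3490 nM

Among the compounds with values here, compound 2 sits within the scatter of compound 1; the one measured step, a 1.2-fold higher number from compound 1 to compound 2 (0.09 log units; within the scatter), is a change of one atom on the oxygen of the aryl ring and does not separate the two numbers.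

Compound 3 `O=C(/C=C/c1cc2ccccc2[nH]c1=O)c1ccc(Cl)cc1` is not yet measured. It differs from compound 2 by chloro in place of hydroxy on an aromatic carbon. Within the data shown here, no measured step touches this change: the only step available exchanges methyl for hydrogen on the oxygen at the same place and is within the scatter. The data give no direction for replacing the oxygen itself by chlorine.

On that basis the expected step of a 1.2-fold lower number from compound 2 to compound 3 (0.10 log units; within the scatter) is small, with the direction left open. Compound 3 is estimated at 2800 nM in this assay, with a range from 900 nM to 9000 nM.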

Compound 3, concentration for 50% growth inhibition: 2410 nM
Compound 3: middle estimate off by 1.2-fold (0.07 log units), on the high side; the measured number falls inside the stated range.
By their numbers in this assay, from the lowest: compounds 3, 1 and 2 (each within the scatter of the next).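

In this assay, chloro in place of hydroxy gives a 1.4-fold lower number from compound 2 to compound 3 (0.16 log units; within the scatter), and chloro in place of methoxy gives a 1.2-fold lower number from compound 1 to compound 3 (0.07 log units; within the scatter). The earlier step changed only what sat on the oxygen; these steps remove the oxygen itself, including the hydrogen-bond donor and acceptor counted for hydroxy, and still leave all three compounds within the scatter of one another at this place, para to a large group. No other measurement bears on this result.

The compounds shown leave open whether this flat reading holds only for hydroxy, methoxy and chloro on the 4-substituted phenyl. An amine, a carboxylic acid or a longer alkoxy chain at the same place could still separate from these three values.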